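The source may hold more compounds than are shown below. What is called first, only, known or untested is meant among the compounds shown, and "the series" means these compounds.

Measured compounds in an assay on isolated protein for inhibition of DNA nucleotidylexotransferase (Homo sapiens), read by scintillation counting, with a stated time of 10 min; a higher number here means a weaker inhibitor, a lower number a stronger inhibitor:
Compound 1, `C/C=C/n1cc(/C=C/C(=O)CC(=O)C(=O)OCC)c2ccccc21`: in this assay compound 1 gives > 40 uM, which is a limit of the assay and not a number.
Compound 2, `C/C=C/Cn1cc(/C=C/C(=O)CC(=O)C(=O)OCC)c2ccccc21`: in this assay compound 2 gives > 40 uM, likewise a limit of the assay.
Compound 3, `CCOC(=O)C(=O)CC(=O)/C=C/c1cn(C=C(C)C)c2ccccc12`: in this assay compound 3 gives > 40 uM, again a limit.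

Compound 2 therefore stands at the limit, and the two further values shown sit at the same limit, so compound 2 cannot be ranked against either of the other two; see (the limit of > 40 uM in this assay, at which 3 of the 3 values shown sit). The three steps among the measured compounds, a step that the two limits leave unreadable from compound 1 to compound 2, a step that the two limits leave unreadable from compound 1 to compound 3 and a step that the two limits leave unreadable from compound 2 to compound 3, all have a limit at both ends and give no readable size. Every variation tried so far on the aromatic nitrogen has left the series at the limit.

Compound 4, `C=C(C)Cn1cc(/C=C/C(=O)CC(=O)C(=O)OCC)c2ccccc21`, differs from compound 2 by 1-methylethenyl in place of prop-1-en-1-yl on a saturated chain carbon bound to an aromatic nitrogen. Among the compounds with values here, no measured step bears a readable size on this change, and all three measured compounds sit on the same side of the limit, so for compound 4 in this assay no step beyond the scatter is expected, the expected step being a step that the limit leaves unreadable from compound 2 to compound 4. Compound 4 is thus estimated to give about 60 uM, in the range 30 uM to 200 uM, and most probably the assay will again report only a limit.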

Compound 4, concentration for 50% inhibition: > 40 uM
Compound 4 ended at the assay's limit; the forecaster's own chance of this, stated with the estimate: 85%; the middle value does not contradict the limit.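

In this assay compound 4 gives > 40 uM, a limit of the assay and not a number. Its steps to compound 1, compound 2 and compound 3 therefore cannot be read, and the series stays at one limit: the limit of > 40 uM in this assay, at which 4 of the 4 values shown sit.

The compounds shown leave open whether any substituent on the aromatic nitrogen gives a readable value.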